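The source may report more compounds than this note shows. Statements on the series, on what has been measured and on what is new or still open speak of the compounds shown alone.

Measured so far in a functional assay on MCF7 cells (Homo sapiens) for inhibition, read by MTT assay, with a stated time of 72 h; a higher number here means a weaker inhibitor, a lower number a stronger inhibitor:
- compound 1 `CCCCc1ccc(NC(=O)C2CCN(C/C=C/c3ccccc3)CC2)cc1`: 5870 nM
- compound 2 `COc1cccc(NC(=O)C2CCN(C/C=C/c3ccccc3)CC2)c1`: 42700 nM
- compound 3 `O=C(Nc1cccc(C(F)(F)F)c1)C1CCN(C/C=C/c2ccccc2)CC1`: 16100 nM

Compound 2, at 42700 nM, has the highest number of the three and so is the weakest inhibitor among them. Compound 3 lies closest to it, and compound 1 lies furthest away.

Compound 4 `O=C(Nc1nccs1)C1CCN(C/C=C/c2ccccc2)CC1` has not yet been measured. It differs from compound 2 by one change: 1,3-thiazol-2-yl in place of 3-methoxyphenyl on an amide-type nitrogen. In words, 1,3-thiazol-2-yl stands in place of 3-methoxyphenyl on an amide-type nitrogen.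

For the measured compounds named here, only one measured step bears on this, and only loosely: a 2.7-fold lower number from compound 2 to compound 3 (0.42 log units; beyond the scatter). Going by the values given here, that step is modest and exchanges a group on the aromatic ring, whereas compound 4 exchanges the whole ring, and no measured compound shows such a swap. A step of similar modest size towards a lower number is therefore expected in this assay, though one within the scatter would not surprise.

The expected step is a 1.6-fold lower number from compound 2 to compound 4 (0.20 log units; within the scatter). For compound 4 the estimated value is 27000 nM, with an expected range of 9000 nM to 80000 nM.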

Compound 4, half-maximal inhibitory concentration: 28600 nM
For compound 4 the middle estimate is 1.1-fold (0.03 log units) below the measured one, within the range that was stated.
By their numbers in this assay, from the lowest: compound 1; then compounds 3, 4 and 2 (each within the scatter of the next, the first and the last beyond it).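

In this assay the exchange on the amide-type nitrogen gives a 1.5-fold lower number from compound 2 to compound 4 (0.17 log units; within the scatter) and so stays within the scatter, even though the whole 3-methoxyphenyl ring is replaced. The earlier step from compound 2 had altered only a group on that ring, whereas compound 4 shows that a five-membered aromatic ring with 2 hetero atoms, with 5 heavy atoms in place of 8, can stand here without a shift beyond the scatter. Nothing available explains why the two rings read alike.

The compounds shown leave open whether a pyridin-2-yl ring would read alike at this nitrogen. They also do not tell what a butyl chain or an amine carried on the 1,3-thiazol-2-yl ring would do to the number.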